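This account rests on a few compounds, and the source may have more. Where it says the series, first, only, none or still open, it means among the compounds named here.

Of the compounds shown here, two from this series have been measured in a functional assay on cells (Homo sapiens) for cytotoxicity, read by propidium iodide staining, with a stated time of 4 days; on this read-out higher numbers stand for weaker inhibition and lower numbers for stronger inhibition. Compound 1 `CNC1=CC(=O)c2c(cnc(C)c2C)C1=O` gives 14400 nM in this assay. Compound 2 `CNC1=CC(=O)c2cc(C)ncc2C1=O`, which carries hydrogen in place of methyl on an aromatic carbon, gives 5210 nM in this assay. That single change produced a 2.8-fold lower number from compound 1 to compound 2 (0.44 log units; beyond the scatter). For the measured compounds named here, compound 2 therefore stands with the lowest of the two numbers measured so far, its nearest neighbour being compound 1.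

Compound 3 `Cc1cc2c(cn1)C(=O)C(NCl)=CC2=O` has not yet been measured. It differs from compound 2 in one place: chloro in place of methyl on an amine nitrogen. Going by the values given here, the only measured step concerns methyl and hydrogen on an aromatic carbon, and none touches the amine nitrogen, so the data give no direct guide to how a chloro in place of a methyl at this position moves the number. In the absence of any bearing step, no movement beyond the scatter is expected, and the expected step is a 1.1-fold higher number from compound 2 to compound 3 (0.02 log units; within the scatter). From the compounds shown here alone, compound 3 is accordingly estimated at 5500 nM, with a range from 1500 nM to 20000 nM, the breadth reflecting that this change is untested.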

Compound 3, half-maximal inhibitory concentration: 1340 nM
Compound 3: the middle estimate sits 4.1-fold (0.61 log units) above what was measured; the whole stated range lies above it.
By their numbers in this assay, from the lowest: compound 3; then compound 2; then compound 1.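

In this assay, the amine nitrogen proves to be a position where the number responds: chloro in place of methyl gives a 3.9-fold lower number from compound 2 to compound 3 (0.59 log units; beyond the scatter). For the compounds shown here, the earlier compounds showed movement only at an aromatic carbon, with a 2.8-fold lower number from compound 1 to compound 2 (0.44 log units; beyond the scatter), so this is the first sign that the group on the amine nitrogen also counts, and it places compound 3 lowest of the three. The change swaps one heavy atom for one heavy atom, with no ring, no charge and no hydrogen-bond donor or acceptor counted on either group, and nothing available explains why the number falls.

From the compounds shown here alone, whether the fall belongs to chloro in particular stays open, since a bromo, an ethyl or a hydroxyl on the same amine nitrogen could show whether other groups move the number in the same way. Going by these compounds, it is also open whether chloro on the amine nitrogen would give a comparable step on the core of compound 1, which carries the additional methyl on an aromatic carbon.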